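Adding a benzyl to a weakly active lactone thiocarbamate

The compounds below may be only part of what the source reports. "The series", "measured", "known", "first", "only" and "open" are said of these compounds alone.

Compound 1 `O=C1OCC[C@@H]1NC(=S)SCCOc1ccc([N+](=O)[O-])cc1` and compound 2 `O=C1OCC[C@@H]1NC(=S)SCCOc1ccccc1` share one core and differ only on the aromatic ring. In a functional assay on PC-3 cells (Homo sapiens) for antiproliferative activity, read by MTT assay, with a stated time of 72 h (on this read-out lower numbers stand for stronger inhibition and higher numbers for weaker inhibition), compound 1 gives 32500 nM. Compound 2 does not give a number in this assay: it reaches only the limit > 64000 nM, and nothing more than that limit is known for it. The step of an at least 1.9-fold higher number from compound 1 to compound 2 (0.29 log units; that floor lies within the scatter) is bounded by the limit of > 64000 nM in this assay, at which 1 of the 2 values shown sits, and shows no clear change. Compound 3 `O=C1OCC[C@@H]1NC(=S)SCCOc1ccccc1Cc1ccccc1` has not yet been measured in this assay. It differs from compound 2 by benzyl in place of hydrogen on an aromatic carbon. For the measured compounds named here, no measured step involves a benzyl or any group of that kind; the only measured step, the loss of a nitro between compound 1 and compound 2, was small and sits at the limit, so it gives little guidance for this new change. Compound 3 is therefore expected to show a step of about an at least 1.2-fold lower number from compound 2 to compound 3 (0.10 log units; that floor lies within the scatter), which is not beyond the scatter. Compound 3 is estimated at 50000 nM, with a range from 15000 nM to 200000 nM.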

Compound 3, half-maximal inhibitory concentration: > 64000 nM
Compound 3: a limit, no number; the forecaster's own chance of this, stated with the estimate: 55%; middle value at least 1.2-fold (0.10 log units) from the limit.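

In this assay compound 3 gives > 64000 nM, which is a limit and not a number. For the compounds shown here, compound 2 also stops at a limit, so no step between the two compounds can be read: the limit of > 64000 nM in this assay, at which 2 of the 3 values shown sit. The compounds shown leave open whether benzyl in place of hydrogen on an aromatic carbon changes the activity at all.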